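The compounds below may be only part of what the source reports. "The series", "measured", "known", "first", "only" and "open" are said of these compounds alone.

Working notes on the series built on the shared core of compound 1 `C#CCSc1nc(NCCC(C)C)c2ccncc2n1`, with compound 2 `C#CCSc1nc(Nc2ccccc2)c2ccncc2n1` and compound 3 `C#CCSc1nc(Nc2ccccc2Cl)c2ccncc2n1` carrying an aryl group on the nitrogen on the aromatic ring in place of the isopentyl. In a functional assay on PC-3 cells (Homo sapiens) for inhibition, read by MTT assay, with a stated time of 72 h (a higher number here means a weaker inhibitor, a lower number a stronger inhibitor), compound 1 gives only a limit, > 80000 nM. Compound 2 likewise reaches only a limit in this assay, > 80000 nM. Compound 3 also stands at a limit in this assay, > 80000 nM. For the measured compounds named here, compound 3 therefore stands nowhere readable on the numbers so far: the steps a step that the two limits leave unreadable from compound 1 to compound 2, a step that the two limits leave unreadable from compound 1 to compound 3 and a step that the two limits leave unreadable from compound 2 to compound 3 cannot be sized, because every value shown sits at the limit of > 80000 nM in this assay, at which 3 of the 3 values shown sit.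

Compound 4 `C#CCSc1nc(Nc2ccccc2OC)c2ccncc2n1` differs from compound 3 by methoxy in place of chloro on an aromatic carbon. Going by the values given here, the one measured step at the same place on the ring, a step that the two limits leave unreadable from compound 2 to compound 3, is the only step that bears on this change, and it is unreadable; the other two steps are equally unreadable. Nothing measured therefore points to a change in either direction beyond the scatter. Compound 4 is expected to stay at the limit as well, estimated at 100000 nM with a range from 30000 nM to 400000 nM. The step that the limit leaves unreadable from compound 3 to compound 4 is thus expected to show nothing readable.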

Compound 4, half-maximal inhibitory concentration: > 80000 nM
Compound 4: a limit, no number; the forecaster's own chance of this, stated with the estimate: 85%; the middle value does not contradict the limit.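

In this assay compound 4 also gives only a limit, > 80000 nM, so the steps to compound 4 from compound 2 and from compound 3 cannot be read, because no value in the series is a number: the limit of > 80000 nM in this assay, at which 4 of the 4 values shown sit.

Compound 1, compound 2, compound 3 and compound 4 leave open whether any change to the group on the nitrogen has an effect in this assay that can be sized.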